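Swapping the aryl group on a small anti-inflammatory scaffold

A few compounds are considered here, and "the series" means these few. Any claim that something is new, unique, unknown or untested is made for them only; others in the source may bear on it.

Measured compounds:
- compound 1 `O=C1N=C(C2C(=O)c3ccccc3C2=O)CC(c2cccc([N+](=O)[O-])c2)N1` — 36%
- compound 2 `O=C1N=C(C2C(=O)c3ccccc3C2=O)CC(c2ccc([N+](=O)[O-])cc2)N1` — 26%
- compound 3 `O=C1N=C(C2C(=O)c3ccccc3C2=O)CC(/C=C/c2ccccc2)N1` — 32%

In a functional assay on the whole organism for inhibition, with Rattus norvegicus as the target, read by paw edema, with stated times of 30 min and 2 h, at a dose of 10 mg/kg by the oral route (on this read-out higher numbers stand for more inhibition at the one dose given (going by the name of the read-out) and lower numbers for less inhibition), compound 1 shows the highest of the three numbers, but only narrowly: compound 3 gives 32% and compound 2 gives 26%, and both steps to compound 1 fall within the scatter of the method, so none of the three can be called more or less effective than another.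

Compound 4 `O=C1N=C(C2C(=O)c3ccccc3C2=O)CC(c2ccc(Cl)cc2)N1` differs from compound 1 in one place: 4-chlorophenyl in place of 3-nitrophenyl on a saturated ring carbon. Going by the values given here, two measured steps bear on this change, since both also replace the 3-nitrophenyl group on the same saturated ring carbon. The step of a number 10 percentage points lower from compound 1 to compound 2 (within the scatter) and the step of a number 4 percentage points lower from compound 1 to compound 3 (within the scatter) were each within the scatter. Nothing in these data therefore suggests that changing the group on this carbon moves the read-out beyond noise, and a step of a number 6 percentage points lower from compound 1 to compound 4 (within the scatter) is expected. Compound 4 is estimated to give 30%, with a likely range from 18% to 42%.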

Compound 4, a percentage reported as inhibition, in the whole organism at one dose (the size of the read-out at that dose, not a potency): 19%
Compound 4: middle estimate off by 11 percentage points, on the high side; the measured number falls inside the stated range.
By their numbers in this assay, from the lowest: compounds 4, 2, 3 and 1 (each within the scatter of the next, the first and the last beyond it).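

Until now, no change of group on this saturated ring carbon had moved the number beyond the scatter, but 4-chlorophenyl does so twice in this assay: it gives a number 17 percentage points lower from compound 1 to compound 4 (beyond the scatter) and a number 13 percentage points lower from compound 3 to compound 4 (beyond the scatter) in a modest but readable shift. The step that swaps only the ring substituent, chloro in place of nitro on an aromatic carbon, is a number 7 percentage points lower from compound 2 to compound 4 (within the scatter) and so cannot separate these two 4-substituted rings, which means the loss is clear only against 3-nitrophenyl and 2-phenylethenyl. Nothing measured here accounts for these steps.

Going by these compounds, it remains open what a plain phenyl group would give on this carbon, and whether a ring carrying an amine or a carboxylic acid would raise or lower the number. The compounds shown also leave open whether any group here can rise clearly above compound 1.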